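Methoxy added to the anilide of a diol cyclopentane acrylamide

The compounds below may be only part of what the source reports. "The series", "measured", "known", "first", "only" and "open" are said of these compounds alone.

compound 1 `O=C(/C=C/[C@H]1C[C@@H](O)[C@@H](O)C1)Nc1ccccc1` — in an ADME assay on S2 cells (Drosophila melanogaster) for cytotoxicity, read by MTT assay (on this read-out lower numbers stand for an effect already at smaller amounts and higher numbers for an effect only at larger amounts of compound), compound 1 gives only a limit, > 200000 nM
compound 2 `CNC(=O)/C=C/[C@H]1C[C@@H](O)[C@@H](O)C1` — compound 2 likewise gives only a limit, > 250000 nM
compound 3 `CCCCNC(=O)/C=C/[C@H]1C[C@@H](O)[C@@H](O)C1` — compound 3 also gives only a limit, > 250000 nM

The three compounds share one core and differ only in the group on the amide nitrogen: phenyl in compound 1, methyl in compound 2, butyl in compound 3. None of them reaches a measurable effect in this assay, so compound 1 stands at a limit, and the two other values are limits as well. The steps among them, a step that the two limits leave unreadable from compound 1 to compound 2, a step that the two limits leave unreadable from compound 1 to compound 3 and a step that the two limits leave unreadable from compound 2 to compound 3, cannot be sized, because one value sits at the limit of > 200000 nM in this assay, at which 1 of the 3 values shown sits, and the others at the limit of > 250000 nM in this assay, at which 2 of the 3 values shown sit.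

Compound 4 `COc1ccc(NC(=O)/C=C/[C@H]2C[C@@H](O)[C@@H](O)C2)cc1` differs from compound 1 by methoxy in place of hydrogen on an aromatic carbon. Within the data shown here, no measured step touches the aromatic ring, so nothing here speaks for a readable change; a step beyond the scatter is not expected. The step of a number no higher from compound 1 to compound 4 (the limit leaves the size open) is therefore an estimate of no change. Compound 4 is expected at about 200000 nM, between 100000 nM and 400000 nM, most likely again as a limit.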

Compound 4, half-maximal effective concentration: > 180000 nM
Compound 4 ended at the assay's limit; the forecaster's own chance of this, stated with the estimate: 85%; the middle value lies beyond the limit too.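

In this assay compound 4 gives > 180000 nM, which is a limit and not a number. Among these compounds, compound 1 also stands at a limit, so no step from compound 1 to compound 4 can be read. The compounds shown leave open how methoxy on the anilide changes the effect in this assay.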